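A Cyano Group Replaces the Amino on Compound 1

The compounds below may be only part of what the source reports. "The series", "measured", "known", "first", "only" and "open" are said of these compounds alone.

Compound 1 `Nc1ccc(NC(=O)c2cn(Cc3c(F)cccc3F)c3ccc(=O)[nH]c3c2=O)cc1` and compound 2 `O=C(Nc1ccccc1)c1cn(Cc2c(F)cccc2F)c2ccc(=O)[nH]c2c1=O` share a core and differ at a single aromatic carbon. In an in vitro assay on Sf21 cells for inhibition of high affinity 3',5'-cyclic-AMP phosphodiesterase 7A (Homo sapiens), read by scintillation proximity assay, with a stated time of 30 min (on this read-out lower numbers stand for stronger inhibition and higher numbers for weaker inhibition), compound 1 gives 104 nM, and compound 2 gives 94 nM. Among the compounds with values here, the only step between the two measured compounds, a 1.1-fold lower number from compound 1 to compound 2 (0.04 log units; within the scatter), puts hydrogen in place of amino on an aromatic carbon. Of the two numbers, compound 1 stands highest, with compound 2 nearest at a gap that lies within the scatter, so no order between them can be claimed.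

Compound 3 `N#Cc1ccc(NC(=O)c2cn(Cc3c(F)cccc3F)c3ccc(=O)[nH]c3c2=O)cc1` has not yet been measured. It differs from compound 1 by cyano in place of amino on an aromatic carbon. Within the data shown here, the one measured step that touches this site, from compound 1 to compound 2, stayed within the scatter, and no other measured step bears on it. On that basis the number for compound 3 is expected to stay close to that of compound 1, with a 1.0-fold lower number from compound 1 to compound 3 (0.02 log units; within the scatter) expected to fall within the scatter in either direction. Compound 3 is therefore estimated at 100 nM, with a range from 40 nM to 250 nM.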

Compound 3, half-maximal inhibitory concentration: 96 nM
Beside the measured number, compound 3's estimate is 1.0-fold (0.02 log units) above it, and the stated range covers the measured number.
By their numbers in this assay, from the lowest: compounds 2, 3 and 1 (each within the scatter of the next).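

Compound 3 gives this aromatic carbon, para to a large group, a third occupant, and this assay does not separate it from the other two: cyano in place of amino gives a 1.1-fold lower number from compound 1 to compound 3 (0.03 log units; within the scatter), and cyano in place of hydrogen gives a 1.0-fold higher number from compound 2 to compound 3 (0.01 log units; within the scatter). Within the data shown here, the earlier step showed only that amino could be replaced by hydrogen, whereas this result adds a replacement with 2 heavy atoms, a triple bond and 0 hydrogen-bond donors, and no step among the three compounds lies beyond the scatter. Nothing measured here accounts for why hydrogen, amino and cyano read alike at this position.

Whether the same holds for a carboxylic acid, a methoxy group or a longer chain at this carbon remains open, since the occupants shown are limited to hydrogen, amino and cyano. The compounds shown also leave open whether a change at any other carbon of this ring, or on the 2,6-difluorobenzyl part of the shared core, would stay within the scatter as well.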